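The compounds below may be only part of what the source reports. "The series", "measured", "known", "first", "only" and "open" are said of these compounds alone.

In a physicochemical assay for solubility, at pH 7.4 (a higher number here means a more soluble compound, a lower number a less soluble compound), compound 1 `O=C(NCc1ccc(-c2noc(CCC3CC3)n2)cc1)[C@H]1NCC[C@@H]1O` reads > 50 ug/mL, which is a limit of the assay and not a number. Compound 2 `CCCCCCCc1cnc(-c2ccc(CNC(=O)[C@H]3NCC[C@@H]3O)cc2)s1`, a different structure, gives 4.2 ug/mL, so a measured number can sit well down the scale for this family. Compound 3 `CCCCCc1nc(-c2ccc(CNC(=O)[C@H]3NCC[C@@H]3O)cc2)no1` changes one place in compound 1 propyl in place of cyclopropyl on a saturated chain carbon, two bonds along the chain from an aromatic carbon. For the measured compounds named here, no measured pair shows this change, so only a modest fall is expected, an estimated at least 1.4-fold lower number from compound 1 to compound 3 (0.15 log units; that floor lies within the scatter). Compound 3 is estimated at 35 ug/mL, with an expected range of 12 ug/mL to 70 ug/mL.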

Compound 3, solubility: > 50 ug/mL
Compound 3 ended at the assay's limit (the forecaster's own chance of this, stated with the estimate: 40%); middle value at least 1.4-fold (0.15 log units) from the limit.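

Compound 1 and compound 3 both end at a limit of this assay rather than at a number, so no step between them can be read: the limit of > 50 ug/mL in this assay, at which 2 of the 3 values shown sit.

As far as these compounds go, whether propyl in place of cyclopropyl changes the read-out at all remains open.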